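Ester group and tolerated concentration on kidney cells

The source may report more compounds than this note shows. Statements on the series, on what has been measured and on what is new or still open speak of the compounds shown alone.

Measured compounds:
compound 1, `CC(C)CCOC(=O)C(O)Cn1cnc2c(N)ncnc21`, 400 ug/mL
compound 2, `CCCOC(=O)C(O)Cn1cnc2c(N)ncnc21`, 100 ug/mL
compound 3, `CCC(C)OC(=O)C(O)Cn1cnc2c(N)ncnc21`, > 400 ug/mL

These three esters share one core and differ only in the group on the oxygen next to the carbonyl group, read in a functional assay on PRK cells (Oryctolagus cuniculus) for cytotoxicity; a lower number here means that less compound is tolerated, a higher number that more compound is tolerated. For compound 3 the value is a limit of the assay rather than a number, > 400 ug/mL, as noted in the limit of > 400 ug/mL in this assay, at which 1 of the 3 values shown sits. Compound 2 gives 100 ug/mL in this assay, and the step of an at least 4.0-fold higher number from compound 2 to compound 3 (0.60 log units; beyond the scatter) takes compound 3 to the limit. Compound 1 gives 400 ug/mL, with a 4.0-fold lower number from compound 1 to compound 2 (0.60 log units; beyond the scatter) and a number no lower from compound 1 to compound 3 (the limit leaves the size open).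

Compound 4, `Nc1ncnc2c1ncn2CC(O)C(=O)OC1CCCCC1`, carries cyclohexyl in place of sec-butyl on an oxygen next to a carbonyl group. Both steps that lead into compound 3 point to a number no lower than that of compound 3, so the step is expected to be a number no higher from compound 3 to compound 4 (the limit leaves the size open), not beyond the scatter. Compound 4 is therefore estimated at 400 ug/mL, within 200 ug/mL to 800 ug/mL, with a real chance that this assay again reports only a limit.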

Compound 4, minimum cytotoxic concentration: 100 ug/mL
The estimate for compound 4 lay 4.0-fold (0.60 log units) above the measured number; the whole stated range lies above it.
By their numbers in this assay, from the lowest: compounds 2 and 4 (each within the scatter of the next); then compound 1.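

Set on this oxygen, cyclohexyl in place of sec-butyl gives an at least 4.0-fold lower number from compound 3 to compound 4 (0.60 log units; beyond the scatter) in this assay, so a carbon ring here does not keep the tolerance seen with the branched chain. Compound 3 stands only at a limit of the assay, which leaves the true size of that step open: the limit of > 400 ug/mL in this assay, at which 1 of the 4 values shown sits. The cyclohexyl ester also compares with the two other esters, with no change at the digits printed from compound 2 to compound 4 (within the scatter) and a 4.0-fold lower number from compound 1 to compound 4 (0.60 log units; beyond the scatter), so the number does not simply follow the size of the group, and compound 2 and compound 4 both go against any such trend.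

As far as these compounds go, whether a cyclopentyl or a phenyl ester would read like compound 3 or like compound 4 remains open. So does the effect of an amine or a carboxylic acid on the ester group.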